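The source may hold more compounds than are shown below. What is called first, only, known or untested is meant among the compounds shown, and "the series" means these compounds.

Three compounds measured in a functional assay on A549 cells (Homo sapiens) for cytotoxicity, read by XTT assay, with a stated time of 72 h (on this read-out lower numbers stand for stronger inhibition and higher numbers for weaker inhibition), set the scene. Compound 1 `CCCCCCCCCCCCCCCCCCc1c(O)cc(O)c(C(C)=O)c1O` gives 32000 nM. Going by the values given here, compound 2 `CC(=O)c1c(O)cc(O)c2c1OC(C)(C)CC2` reaches only > 100000 nM, which is a limit of the assay rather than a number, and it is the one value of the three that sits at the limit of > 100000 nM in this assay, at which 1 of the 3 values shown sits. Compound 3 `CC(C)=CCC/C=C(\C)Cc1c(O)cc(O)c2c(=O)c(OC/C=C(\C)CCC=C(C)C)c(-c3ccc(O)cc3)oc12` gives 26000 nM, the lowest of the two numbers, though its gap to compound 1 lies within the usual scatter, so neither can be called the more active of the pair.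

Compound 4 `CC(C)=CCC/C=C(\C)Cc1c(O)cc(O)c2c(=O)c(O)c(-c3ccc(O)cc3)oc12` has not yet been measured. It differs from compound 3 in one place: hydrogen in place of 3,7-dimethylocta-2,6-dien-1-yl on an oxygen on an aromatic ring. Among the compounds with values here, no measured pair in this set shares this kind of change, so there is no direct guide to its effect. Compound 4 is expected to give a number close to compound 3, with the step of a 1.5-fold higher number from compound 3 to compound 4 (0.19 log units; within the scatter) estimated as a small weakening that may well lie within the scatter, and compound 4 is estimated at 40000 nM, within a range from 15000 nM to 100000 nM.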

Compound 4, half-maximal inhibitory concentration: 26000 nM
Estimate against measurement, compound 4: 1.5-fold (0.19 log units) above; measured number inside the range.
By their numbers in this assay, from the lowest: compounds 3, 4 and 1 (each within the scatter of the next). At a limit, above all of these: compound 2.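

Taking the 3,7-dimethylocta-2,6-dien-1-yl group off this oxygen on an aromatic ring and leaving hydrogen gives no change at the digits printed from compound 3 to compound 4 (within the scatter) in this assay. Going by these compounds alone, this is the first pair that differs in one place, and it shows that this position can carry either the whole chain or a bare hydroxy group with no readable difference on this read-out. No measurement shown here explains why the two compounds read alike.

Still open, going by these compounds, is whether a small group on this oxygen, such as methyl or acetyl, or a chain ending in an amine or a carboxylic acid, would move the number beyond the scatter. The part played by the other chain on the shared core also remains unknown, as no pair shown changes it alone.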